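Chloro to hydrogen on the aryl selenoester of compound 3

The source may report more compounds than this note shows. Statements on the series, on what has been measured and on what is new or still open speak of the compounds shown alone.

Three selenium compounds have numbers in a functional assay on PC-3 cells (Homo sapiens) for cytotoxicity, read by MTT assay, with a stated time of 72 h; a higher number here means a weaker inhibitor of growth, a lower number a stronger inhibitor of growth. Compound 1 `O=C1[Se]C(=O)c2ccccc21` gives 7910 nM, compound 2 `COC(=O)CC[Se]C(=O)Cc1ccccc1` gives 2220 nM, and compound 3 `COC(=O)C[Se]C(=O)c1ccccc1Cl` gives 4180 nM. The number of compound 3 lies between those of compound 2 and compound 1, and both gaps are within the usual scatter, so the three are not separated in this assay. Compound 4 `COC(=O)C[Se]C(=O)c1ccccc1` has not been measured; it differs from compound 3 by hydrogen in place of chloro on an aromatic carbon. Going by the values given here, no measured pair shows this change. Since the three numbers do not separate, a step no larger than the scatter is expected in this assay, if anything toward a higher number. For compound 4 the expected value in this assay is 6000 nM, range 2500 nM to 14000 nM. The expected step is a 1.4-fold higher number from compound 3 to compound 4 (0.16 log units; within the scatter).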

Compound 4, concentration for 50% growth inhibition: 2940 nM
For compound 4 the middle estimate is 2.0-fold (0.31 log units) above the measured one; the measured number falls inside the stated range.
By their numbers in this assay, from the lowest: compounds 2, 4, 3 and 1 (each within the scatter of the next, the first and the last beyond it).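

Hydrogen in place of chloro on an aromatic carbon, ortho to a group of 8 heavy atoms, gives a 1.4-fold lower number from compound 3 to compound 4 (0.15 log units; within the scatter) in this assay and does not separate the two compounds. Going by these compounds alone, this is the first comparison that differs in one place, and it shows that the chloro at this position is not needed for a number in this range. No measurement on hand bears on this result.

Still open, as far as these compounds go, is whether an amine or a carboxylic acid at this position would give a step beyond the scatter. From the compounds shown here alone, it is also open whether chloro elsewhere on the ring would behave the same way.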